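Swapping a side chain on compound 1 for acetyl

The source may report more compounds than this note shows. Statements on the series, on what has been measured and on what is new or still open speak of the compounds shown alone.

Compound 1 `COC(=O)[C@]1(Cc2ccc(O)c(CC=C(C)C)c2)OC(=O)C(O)=C1c1ccc(OC)cc1`: < 10000 nM as a limit
Compound 2 `COC(=O)[C@]1(Cc2ccc(O)c(CC=C(C)C)c2)OC(=O)C(O)=C1c1ccccc1`: < 10000 nM as a limit

In a functional assay on HepG2 cells (Homo sapiens) for cytotoxicity, read by MTT assay (on this read-out lower numbers stand for stronger inhibition and higher numbers for weaker inhibition), compound 1 gives < 10000 nM as a limit, not a number. Its place on the scale is therefore known only as the limit of < 10000 nM in this assay, at which 2 of the 2 values shown sit, and cannot be pinned down further.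

The next compound to be measured is compound 3 `COC(=O)[C@]1(Cc2ccc(O)c(CC(C)=O)c2)OC(=O)C(O)=C1c1ccc(OC)cc1`, which keeps the core of compound 1 but has acetyl in place of 2-methylprop-1-en-1-yl on a saturated chain carbon bound to an aromatic carbon. Cut one bond further out, the same difference reads 3-methylbut-2-en-1-yl to 2-oxopropyl.

Going by the values given here, the only measured step is a step that the two limits leave unreadable from compound 1 to compound 2 and it involves a different change, hydrogen in place of methoxy on an aromatic carbon. Among the compounds with values here, it offers no size to carry over, and no measured step tests the side chain itself. The data therefore point to no direction in this assay and the working expectation is no change beyond the scatter, held with wide uncertainty. The expected size is a step that the limit leaves unreadable from compound 1 to compound 3 for now. For compound 3 the estimated value is 6000 nM (expected range 1500 nM to 25000 nM).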

Compound 3, half-maximal inhibitory concentration: < 10000 nM
Compound 3 gave a limit, no number; the forecaster's own chance of this, stated with the estimate: 50%; the middle value does not contradict the limit.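

Compound 3, like compound 1, gives only a limit and not a number in this assay, so the step between them cannot be read: the limit of < 10000 nM in this assay, at which 3 of the 3 values shown sit.

The compounds shown leave open where any of them sits as an actual number on this scale, and so whether acetyl in place of 2-methylprop-1-en-1-yl changes the result at all.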